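A few compounds are considered here, and "the series" means these few. Any claim that something is new, unique, unknown or untested is made for them only; others in the source may bear on it.

Measured so far in a functional assay on HL-60 cells (Homo sapiens) for inhibition, read by sulforhodamine B assay, with a stated time of 48 h, tested at 10 uM; on this read-out lower numbers stand for less inhibition and higher numbers for more inhibition at the one concentration tested (going by the name of the read-out):

Compound 1, `c1ccc(-c2cn3ccnc3c(-c3ccc4ncn(C5CCCCC5)c4c3)n2)cc1`: compound 1 gives 67.1%
Compound 2, `c1cn2cc(-c3ccsc3)nc(-c3ccc4ncn(C5CCCCC5)c4c3)c2n1`: compound 2 gives 18.5%
Compound 3, `CC(=O)c1ccc(-c2cn3ccnc3c(-c3ccc4ncn(C5CCCCC5)c4c3)n2)cc1`: compound 3 gives 2.65%

Compound 3 stands lowest of the three numbers: nearest is compound 2, and the gap a number 15.9 percentage points lower from compound 2 to compound 3 (beyond the scatter) is beyond the scatter; furthest is compound 1, with the step of a number 64.5 percentage points lower from compound 1 to compound 3 (beyond the scatter). That last step is the one that bears most on the next compound, since it shows what putting acetyl in place of hydrogen on the aromatic carbon did.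

Compound 4, `Brc1ccc(-c2cn3ccnc3c(-c3ccc4ncn(C5CCCCC5)c4c3)n2)cc1`, differs from compound 3 as follows: bromo in place of acetyl on an aromatic carbon.

Among the measured compounds shown here, no measured step replaces acetyl with bromo, so the bearing is indirect. Compound 1, with hydrogen at that position, sits far higher than compound 3, so removing acetyl is expected to recover part of that loss; bromo is not hydrogen, however, and the size of the recovery is uncertain. In this assay compound 4 is therefore expected to move upward by about a number 32.4 percentage points higher from compound 3 to compound 4 (beyond the scatter), landing near 35% with a range of 5% to 68%.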

Compound 4, a percentage reported as inhibition, at one concentration (the size of the read-out at that concentration, not a potency): 23.2%
For compound 4 the middle estimate is 11.8 percentage points above the measured one; measured number inside the range.
By their numbers in this assay, from the lowest: compound 3; then compounds 2 and 4 (each within the scatter of the next); then compound 1.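

In this assay, bromo on the six-membered aromatic ring, para to a large group, also lies well under hydrogen, at a number 43.9 percentage points lower from compound 1 to compound 4 (beyond the scatter) for this change, so the drop at this place is not confined to acetyl. The two substituents still differ, with a number 20.6 percentage points higher from compound 3 to compound 4 (beyond the scatter) when bromo replaces acetyl, so the size of the drop depends on the group; on the ring swap, 4-bromophenyl and thiophen-3-yl cannot be told apart, at a number 4.7 percentage points higher from compound 2 to compound 4 (within the scatter) in this comparison. Nothing on hand gives a reason for these steps.

From the compounds shown here alone, whether every substituent at this place lowers the number, or whether an amine, a methoxy group or a carboxylic acid here would stay close to compound 1, remains open. Also open, going by these compounds, is whether bromo on another carbon of the same ring would give the same result.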